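Thiomorpholine urea in place of sulfone amide

The source may hold more compounds than are shown below. What is called first, only, known or untested is meant among the compounds shown, and "the series" means these compounds.

Compound 1, `CC(C)(C)c1cc(NC(=O)[C@@H]2CCCCN2C2CC2)no1`, in an ADME assay (liver) for metabolic stability, with Liver microsome (Homo sapiens) as the target, read by LC-MS, using microsomes and NADPH, tested at 1 uM (on this read-out lower numbers stand for a shorter-lived compound and higher numbers for a longer-lived compound), gives 0.183 h.
Compound 2, `CC(C)(C)c1cc(NC(=O)[C@@H]2CCCCN2CC2CC2)no1`, gives 0.15 h in this assay.
Compound 3, `CC(C)(C)c1cc(NC(=O)[C@@H]2CCCCN2C(=O)C2CCS(=O)(=O)CC2)no1`, reaches only the upper limit of this assay, > 2 h, and no number.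

Going by the values given here, compound 3 sits at the limit (the limit of > 2 h in this assay, at which 1 of the 3 values shown sits); it is the one value of the three that is not a number. Compound 4 is `CC(C)(C)c1cc(NC(=O)[C@@H]2CCCCN2C(=O)N2CCSCC2)no1`, with thiomorpholin-4-yl in place of 1,1-dioxothian-4-yl on a carbonyl carbon. Among the compounds with values here, only one measured step exists, a 1.2-fold lower number from compound 1 to compound 2 (0.09 log units; within the scatter), and it concerns a different position, so nothing measured bears on this change. Compound 4 is expected to fall below the limit, a step of an at least 1.6-fold lower number from compound 3 to compound 4 (0.22 log units; that floor lies within the scatter), and its half-life in this assay is estimated at 1.2 h, within 0.4 h to 3 h.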

Compound 4, half-life: < 0.0834 h
Compound 4: no number, only a limit (the forecaster's own chance of this, stated with the estimate: 35%); at least 14-fold (1.15 log units) between middle value and limit.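

In this assay, going by these compounds alone, the change on the carbonyl carbon gives an at least 23-fold lower number from compound 3 to compound 4 (1.37 log units; beyond the scatter), the first step at this position and a large one. Compound 4 stands at a limit and has no number: the limit of < 0.0834 h in this assay, at which 1 of the 4 values shown sits. Set against the groups on the amine nitrogen in a ring, (thiomorpholin-4-yl)carbonyl gives an at least 2.1-fold lower number from compound 1 to compound 4 (0.34 log units; beyond the scatter) and an at least 1.7-fold lower number from compound 2 to compound 4 (0.25 log units; that floor lies within the scatter), so compound 4 shows no gain over either.

Going by these compounds, the ring sulfur and the atom joining the ring to the carbonyl carbon change together in this step, and their shares remain open. A 1,1-dioxothiomorpholin-4-yl group on that carbonyl carbon would separate them.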